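Adenosine-Like Antiproliferatives: A Benzylamine Swap on HL-60 Cells

This account rests on a few compounds, and the source may have more. Where it says the series, first, only, none or still open, it means among the compounds named here.

Measured so far:
- compound 1, `OC[C@H]1O[C@@H](n2cnc3c(NCc4ccc(Cl)c(Cl)c4)ncnc32)[C@H](O)[C@@H]1O`: 2000 nM
- compound 2, `COc1ccc(CNc2ncnc3c2ncn3C2OC(CO)[C@@H](O)[C@H]2O)c(O)c1`: "not determined" (no result reported)
- compound 3, `COc1cc(O)cc(OC)c1CNc1ncnc2c1ncn2[C@@H]1O[C@H](CO)[C@@H](O)[C@H]1O`: "not determined" (no result reported)

Three compounds share a common core and differ only in the group carried on a saturated chain carbon bound to a nitrogen on an aromatic ring. In a functional assay on HL-60 cells (Homo sapiens) for antiproliferative activity, with a stated time of 72 h (on this read-out lower numbers stand for stronger inhibition and higher numbers for weaker inhibition), compound 1 gives 2000 nM. For the measured compounds named here, this is the only number in the set: in this assay compound 2 gives "not determined" (no result reported) and compound 3 gives "not determined" (no result reported), so compound 1 cannot be placed above or below any neighbour, and no step between measured compounds is available.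

The compound not yet measured is compound 4, `Cc1ccc(O)c(CNc2ncnc3c2ncn3[C@@H]2O[C@H](CO)[C@@H](O)[C@H]2O)c1`. Relative to compound 1 the change is 2-hydroxy-5-methylphenyl in place of 3,4-dichlorophenyl on a saturated chain carbon bound to a nitrogen on an aromatic ring. Going by the values given here, no pair of measured compounds brackets this kind of exchange. Nothing in the present data says how large the step should be or which way it should run. The expectation is therefore cautious: a step from compound 1 to compound 4 of about a 1.5-fold higher number from compound 1 to compound 4 (0.18 log units; within the scatter) in this assay, which is expected to stay near or just beyond the usual scatter, with the wide range reflecting the absence of any guiding comparison.

Compound 4 is thus estimated at 3000 nM, with a plausible span from 800 nM to 12000 nM.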

Compound 4, half-maximal inhibitory concentration: 15000 nM
For compound 4 the middle estimate is 5.0-fold (0.70 log units) below the measured one; measured number outside the range, above it.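

In this assay, the group on a saturated chain carbon bound to a nitrogen on an aromatic ring now proves able to move the read-out: 2-hydroxy-5-methylbenzyl in place of 3,4-dichlorobenzyl gives a 7.5-fold higher number from compound 1 to compound 4 (0.88 log units; beyond the scatter), the first step the set offers, and it lies beyond the scatter. The two groups match at 8 heavy atoms and one six-membered aromatic ring of carbon only, so the number shifts even though those counts stay the same; they differ in that the entering group has 1 hydrogen-bond donor and 1 hydrogen-bond acceptor and the leaving group has neither. No measurement here accounts for the step, and the exchange alters the ring's substituents all at once, so no single part of it can be singled out.

For the compounds shown here, compounds 2 and 3 carry no number, so no step involving them can be read, and the separate contributions of the hydroxy group, the methyl group and the two chlorine atoms stay open. From the compounds shown here alone, it also remains open how this position would respond to a carboxylic acid or a dimethylamino group on the phenyl ring, or to a longer chain such as phenethyl in place of the benzyl group.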